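Cytotoxicity of oxadiazole benzoic acids: a bromomethyl swapped for trifluoromethyl

This account rests on a few compounds, and the source may have more. Where it says the series, first, only, none or still open, it means among the compounds named here.

Measured compounds:
- compound 1 `O=C(O)c1cccc(-c2noc(CCl)n2)c1`: 64900 nM
- compound 2 `O=C(O)c1ccc(-c2noc(CBr)n2)cc1`: 81900 nM
- compound 3 `COC(=O)c1ccc(-c2noc(CBr)n2)cc1`: 32700 nM

In an ADME assay on MT2 cells (Homo sapiens) for cytotoxicity, read by XTT assay, with a stated time of 4 days (on this read-out higher numbers stand for lower toxicity in this test and lower numbers for higher toxicity in this test), compound 2 gives the highest of the three numbers. Compound 1 sits nearest to it, a gap that lies within the scatter, so the two cannot be told apart. Among the measured compounds shown here, compound 3 lies furthest away, and the step of a 2.5-fold lower number from compound 2 to compound 3 (0.40 log units; beyond the scatter) is the only change among the measured compounds that moved the read-out beyond the scatter; it concerns the methyl on an oxygen next to a carbonyl group, not the five-membered ring.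

Compound 4 `O=C(O)c1ccc(-c2noc(C(F)(F)F)n2)cc1` differs from compound 2 in a different place: trifluoromethyl in place of bromomethyl on an aromatic carbon, the group sitting on an aromatic carbon of a five-membered aromatic ring with 2 nitrogen and 1 oxygen. For the measured compounds named here, no measured step touches that position, so nothing among the measured compounds tells how the read-out responds there. The step from compound 2 to compound 4 is therefore expected to stay within the scatter, a 1.1-fold higher number from compound 2 to compound 4 (0.04 log units; within the scatter), and compound 4 is estimated at 90000 nM, with a range from 40000 nM to 200000 nM.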

Compound 4, half-maximal cytotoxic concentration: 82300 nM
Compound 4: the middle estimate sits 1.1-fold (0.04 log units) above what was measured; measured number inside the range.
By their numbers in this assay, from the lowest: compounds 3, 1, 2 and 4 (each within the scatter of the next, the first and the last beyond it).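

In this assay this position on the five-membered ring now has a reading of its own: trifluoromethyl in place of bromomethyl gives a 1.0-fold higher number from compound 2 to compound 4 (0.00 log units; within the scatter) and leaves the two compounds indistinguishable. Among the compounds shown here, the only earlier step that could be read, a 2.5-fold lower number from compound 2 to compound 3 (0.40 log units; beyond the scatter) in the same test, concerned the methyl on an oxygen next to a carbonyl group and said nothing about this ring carbon, whereas this pair shows that one exchange here, to a group with more heavy atoms, produces no difference that can be told from the scatter. Nothing measured here gives a reason why these two groups read alike.

This single pair cannot show how the position behaves in general, so an amine or a longer chain on the same ring carbon could read alike or quite differently. From the compounds shown here alone, it also remains open whether trifluoromethyl would read the same way on the methyl ester of compound 3, where the acid is already capped.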